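One carbon off a long chain

The source may report more compounds than this note shows. Statements on the series, on what has been measured and on what is new or still open speak of the compounds shown alone.

- compound 1 `C=CC/N=C/N1CCC(C(c2ccccc2)c2ccccc2)CC1` gives 10.4 mg/kg
- compound 2 `CCCCCCCCC/N=C/N1CCC(C(c2ccccc2)c2ccccc2)CC1` gives 10.8 mg/kg

Among the compounds with values here, in a functional assay on the whole organism (stomach) with Rattus norvegicus as the target (on this read-out lower numbers stand for an effect already at smaller amounts and higher numbers for an effect only at larger amounts of compound), compound 2 stands level with compound 1, the only other compound measured so far. Compound 3 `CCCCCCCC/N=C/N1CCC(C(c2ccccc2)c2ccccc2)CC1` differs from compound 2 by hydrogen in place of methyl on a saturated chain carbon, eight bonds along the chain from a double-bonded nitrogen with hydrogen in place of methyl on a saturated chain carbon, eight bonds along the chain from a double-bonded nitrogen. Within the data shown here, one measured step bears on this change, octyl in place of vinyl. Because of a 1.0-fold higher number from compound 1 to compound 2 (0.02 log units; within the scatter) for that larger swap, no step beyond the scatter is expected in this assay here. The expected step is a 1.0-fold lower number from compound 2 to compound 3 (0.01 log units; within the scatter) and so stays small. Compound 3 is estimated at 10.6 mg/kg with a range from 5.5 mg/kg to 20 mg/kg on this read-out.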

Compound 3, dose for half-maximal effect: 10.9 mg/kg
Compound 3: the middle estimate sits 1.0-fold (0.01 log units) below what was measured; low and high end bracket the measured number.
By their numbers in this assay, from the lowest: compounds 1, 2 and 3 (each within the scatter of the next).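

In this assay hydrogen in place of methyl on a saturated chain carbon, eight bonds along the chain from a double-bonded nitrogen, gives a 1.0-fold higher number from compound 2 to compound 3 (0.00 log units; within the scatter) and so stays within the scatter. Heptyl in place of vinyl gives a 1.0-fold higher number from compound 1 to compound 3 (0.02 log units; within the scatter) and also stays within the scatter, so compound 1, compound 2 and compound 3 all stand level. Nothing shown gives a reason for this. Going by these compounds, whether a longer chain, or an amine or a carboxylic acid on this chain carbon, would move the number stays open.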